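The source may hold more compounds than are shown below. What is called first, only, known or untested is meant among the compounds shown, and "the series" means these compounds.

compound 1 `CC(=O)N[C@@H]1CCN(c2cc(C)nn3c(-c4ccc(C#N)cc4)c(C)nc23)C1` value > 95%
compound 2 `COc1ccc(-c2c(C)nc3c(N4CC[C@@H](NC(C)=O)C4)cc(C)nn23)cc1F` value > 95%

In an ADME assay on microsomes from liver (Mus musculus) for metabolic stability, read by LC-MS, with NADPH named in the record, with a stated time of 60 min, tested at 1 uM, in the absence of a further agent (a higher number here means that more of the compound is left, a lower number that less of the compound is left), compound 2 gives > 95% as a limit of the assay, not a number. Compound 1 gives > 95% as a limit too. The evidence so far is only the limit of > 95% in this assay, at which 2 of the 2 values shown sit, and no exact figure. Compound 3 `CSc1ccc(-c2c(C)nc3c(N4CC[C@@H](NC(C)=O)C4)cc(C)nn23)cc1` carries 4-(methylsulfanyl)phenyl in place of 3-fluoro-4-methoxyphenyl on an aromatic carbon, and 4-(methylsulfanyl)phenyl in place of 3-fluoro-4-methoxyphenyl on an aromatic carbon gives the count. Within the data shown here, the one measured step at this place is a step that the two limits leave unreadable from compound 1 to compound 2 and offers no size to carry over. The limit leaves only a fall readable, and the estimated change is a number at least 10 percentage points lower from compound 2 to compound 3 (that floor lies within the scatter) and expected to be modest. For compound 3 the estimate is 85% within an expected range of 60% to 98% in this measurement.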

Compound 3, percent of the compound remaining: > 95%
Compound 3 gave a limit, no number (the forecaster's own chance of this, stated with the estimate: 35%); middle value at least 10 percentage points away from the limit.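

No step can be read among compound 1, compound 2 and compound 3, since each result is a limit of the assay, not a number: the limit of > 95% in this assay, at which 3 of the 3 values shown sit.

The compounds shown leave open whether these three phenyl groups differ at all in this assay.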